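This account rests on a few compounds, and the source may have more. Where it says the series, first, only, none or still open, it means among the compounds named here.

Of the compounds shown here, two have been tested in a functional assay on Raji cells (Homo sapiens) for cytotoxicity, with a stated time of 72 h; on this read-out lower numbers stand for an effect already at smaller amounts and higher numbers for an effect only at larger amounts of compound: compound 1 (`C=C[C@@](C)(/C=C/c1ccc(O)cc1)CC/C=C(C)/C=N/N`) and compound 2 (`C=C[C@@](C)(/C=C/c1ccc(O)c(/C=C/C#N)c1)CCC=C(C)C`). Compound 1 gives > 26000 nM as a limit of the assay. Compound 2 gives > 26000 nM as a limit as well, so no actual number is available for it on this read-out. Among the measured compounds shown here, the whole record so far is the limit of > 26000 nM in this assay, at which 2 of the 2 values shown sit, and offers no measured step to work from. Compound 3 (`C=C[C@@](C)(/C=C/c1ccc(O)c(/C=C/C=C/c2ccccc2)c1)CCC=C(C)C`) has 2-phenylethenyl in place of cyano on a double-bonded chain carbon bound to a double-bonded chain carbon. The expected change, an at least 1.4-fold lower number from compound 2 to compound 3 (0.15 log units; that floor lies within the scatter) in this assay, is a modest one toward lower numbers, and this is a tentative expectation, since compound 3 could equally well stop at the limit. Compound 3 is estimated at 18000 nM (range 6000 nM to 40000 nM).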

Compound 3, half-maximal effective concentration: > 26000 nM
Compound 3 gave a limit, no number (the forecaster's own chance of this, stated with the estimate: 55%); at least 1.4-fold (0.15 log units) between middle value and limit.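

No step can be read between compound 2 and compound 3, since both give only a limit and no number: the limit of > 26000 nM in this assay, at which 3 of the 3 values shown sit. The compounds shown leave open whether any change on the shared core would give an actual number in this assay.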